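The source may report more compounds than this note shows. Statements on the series, on what has been measured and on what is new or still open speak of the compounds shown alone.

Measured so far:
compound 1 `COc1ccccc1CSc1nc2cc(NC(=O)C3CC3)ccc2n1C(C)C` — in an assay on isolated protein for inhibition of Gonadotropin-releasing hormone receptor (Rattus norvegicus) (on this read-out higher numbers stand for weaker inhibition and lower numbers for stronger inhibition), compound 1 gives > 10000 nM, a limit of the assay.
compound 2 `COc1ccc(C(C)=O)cc1CSc1nc2cc(NC(=O)C3CC3)ccc2n1C(C)C` — in this assay compound 2 gives > 10000 nM, likewise a limit.
compound 3 `CCCn1c(SCc2cc([N+](=O)[O-])ccc2OC)nc2cc(NC(=O)NC(C)(C)C)cc(C(=O)N(C)C)c21` — in this assay compound 3 gives 200 nM.

Going by the values given here, compound 3 therefore holds the only number among the three values; compound 1 and compound 2 stand at a limit, (the limit of > 10000 nM in this assay, at which 2 of the 3 values shown sit). Among the compounds with values here, the one measured step, a step that the two limits leave unreadable from compound 1 to compound 2, concerns a different change and cannot be read, so no measured step bears on the way from compound 3 to compound 4 `CCCn1c(SCc2cc([N+](=O)[O-])ccc2OC)nc2cc(NC(=O)NC(C)(C)C)cc(C(=O)NCCCN(C)C)c21`, where ((3-(dimethylamino)propyl)amino in place of dimethylamino on a carbonyl carbon). Within the data shown here, with no step to lean on, the estimated step of no change at the digits printed from compound 3 to compound 4 (within the scatter) is expected to lie within the scatter. Compound 4 is thus estimated at 200 nM, with a range from 60 nM to 700 nM.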

Compound 4, half-maximal inhibitory concentration: 19 nM
Beside the measured number, compound 4's estimate is 11-fold (1.02 log units) above it; the measured number lies below the stated range.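

With this assay, this carbonyl carbon proves sensitive to the group it carries: (3-(dimethylamino)propyl)amino in place of dimethylamino gives an 11-fold lower number from compound 3 to compound 4 (1.02 log units; beyond the scatter). This is the first readable step among the compounds shown, and it comes from a change that adds one hydrogen-bond donor and one hydrogen-bond acceptor. Nothing among the data shown accounts for the size of this step. As far as these compounds go, whether it follows the amide hydrogen, the propyl chain or the dimethylamino of the new group stays open. A longer chain, or a carboxylic acid in place of that dimethylamino, would help to separate these.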